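Benzyloxy extension of the cyclohexyl-bearing analogue

A few compounds are considered here, and "the series" means these few. Any claim that something is new, unique, unknown or untested is made for them only; others in the source may bear on it.

Compound 3 `COc1ccc(-c2c(C)[nH]c(=O)n2C2CCCCC2)cc1` gives the lowest number of the three measured in a functional assay on brain (Rattus norvegicus, strain Wistar) for inhibition (a lower number here means a stronger inhibitor, a higher number a weaker inhibitor), at 20400 nM. Compound 1 `Cc1ccc(-c2c(C)[nH]c(=O)n2C)cc1` sits higher in this assay at 85300 nM, and compound 2 `COc1ccc(-c2c(C)[nH]c(=O)n2C)cc1` higher still at 147000 nM; both gaps to compound 3 lie beyond the scatter. Two single-point steps connect the measured set: a 1.7-fold higher number from compound 1 to compound 2 (0.24 log units; within the scatter) and a 7.2-fold lower number from compound 2 to compound 3 (0.86 log units; beyond the scatter).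

Compound 4 `Cc1[nH]c(=O)n(C2CCCCC2)c1-c1ccc(OCc2ccccc2)cc1` differs from compound 3 by phenyl in place of hydrogen on a saturated chain carbon bound to an oxygen on an aromatic ring. For the measured compounds named here, no measured step alters this position in the same way. The step of a 1.7-fold higher number from compound 1 to compound 2 (0.24 log units; within the scatter) touched the same oxygen-bearing group and stayed within the scatter. The step of a 7.2-fold lower number from compound 2 to compound 3 (0.86 log units; beyond the scatter) shows that enlarging a carbon-only substituent elsewhere on the shared core lowered the number modestly. Going by the values given here, on this basis a modest lowering, or no change beyond the scatter, is the expected outcome for this assay; with only two steps available the range is kept wide.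

Compound 4 is therefore expected to give about 10000 nM in this assay, within 3000 nM to 40000 nM, which corresponds to an expected step of a 2.0-fold lower number from compound 3 to compound 4 (0.31 log units; beyond the scatter).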

Compound 4, half-maximal inhibitory concentration: 8300 nM
Compound 4: middle estimate off by 1.2-fold (0.08 log units), on the high side; measured number inside the range.
By their numbers in this assay, from the lowest: compound 4; then compound 3; then compounds 1 and 2 (each within the scatter of the next).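

In this assay, for the compounds shown here, extending methoxy to benzyloxy gives a 2.5-fold lower number from compound 3 to compound 4 (0.39 log units; beyond the scatter), the first change at this oxygen-bearing group to move the number beyond the scatter, as the earlier methoxy in place of methyl step did not. The position therefore accepts phenyl on the saturated chain carbon bound to the oxygen, with a modest lowering of the number rather than a loss. Nothing available here bears on why the number falls with this change.

The compounds shown leave open whether the phenyl ring itself is needed, or whether a plain carbon chain such as butoxy would serve equally at this place. They also leave open whether a carboxylic acid or an amine carried on the benzyl group would keep the lower number, and whether benzyloxy gives a similar step with methyl on the aromatic nitrogen.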